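The compounds below may be only part of what the source reports. "The series", "measured", "known", "first", "only" and "open" are said of these compounds alone.

Measured so far:
compound 1 `CN(c1ncco1)c1cnc(NCc2c(F)ccc3c2CCO3)n2cnnc12` gives 2.1 in a physicochemical assay for lipophilicity, using the shake flask method, in phosphate buffer, measured as octanol-water partition, with a stated time of 30 min, at pH 7.4; a higher number here means a more lipophilic compound, a lower number a more polar compound;
compound 2 `CNC(=O)c1ncc(-c2cnc(NCc3c(F)ccc4c3CCO4)c3cn[nH]c(=O)c23)n1C` gives 2.5 in this assay.

Compound 1 holds the lower of the two numbers; compound 2 stands higher, beyond the usual scatter. Compound 3 `O=C1CC2(CC2)CN1c1cnc(NCc2c(F)ccc3c2CCO3)n2cnnc12` has not yet been measured. It differs from compound 1 in one place a group of 8 heavy atoms (6 carbon, 1 nitrogen, 1 oxygen; one three-membered non-aromatic ring of carbon only, one five-membered non-aromatic ring with 1 hetero atom) in place of a group of 7 heavy atoms (4 carbon, 2 nitrogen, 1 oxygen; one five-membered aromatic ring with 2 hetero atoms), on an aromatic carbon on an aromatic carbon of the shared core. Among the compounds with values here, no measured pair shows this change, so the expectation rests on compound 1 alone. From compound 1 the expected step is a number 0.10 log units lower from compound 1 to compound 3 (within the scatter), not beyond the scatter. Compound 3 is therefore estimated at about 2, between 1.5 and 2.6.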

Compound 3, distribution coefficient: 1.9
For compound 3 the middle estimate is 0.10 log units above the measured one, and the stated range covers the measured number.
By their numbers in this assay, from the lowest: compounds 3 and 1 (each within the scatter of the next); then compound 2.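

In this assay, replacing the methyl(1,3-oxazol-2-yl)amino group with the group holding a three-membered carbon ring and a five-membered non-aromatic ring gives a number 0.20 log units lower from compound 1 to compound 3 (within the scatter) at this aromatic carbon of the shared core. This shows that a five-membered aromatic ring here can give way to two non-aromatic rings with no step beyond the scatter. Nothing available explains this result. Open still is how a carboxylic acid or a primary amine at this position would read, and whether a longer chain would stay within the scatter of compound 1.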